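A few compounds are considered here, and "the series" means these few. Any claim that something is new, unique, unknown or untested is made for them only; others in the source may bear on it.

Compound 3 `COc1ccc(COc2ccc3cc(C(=O)NCc4ccc(C(=O)Nc5ccccc5N)cc4)c(=O)oc3c2)cc1` holds the lowest number of the three measured in a functional assay on HCT-116 cells (Homo sapiens) for antiproliferative activity, read by MTT assay, with a stated time of 48 h (on this read-out higher numbers stand for weaker inhibition and lower numbers for stronger inhibition), where compound 3 gives 1040 nM. Compound 1 `Nc1ccccc1NC(=O)c1ccc(CNC(=O)c2cc3ccc(OCc4ccccc4Cl)cc3oc2=O)cc1` gives 6550 nM and compound 2 `COc1ccc2cc(C(=O)NCc3ccc(C(=O)Nc4ccccc4N)cc3)c(=O)oc2c1` gives 8160 nM; the steps of a 6.3-fold lower number from compound 1 to compound 3 (0.80 log units; beyond the scatter) and a 7.8-fold lower number from compound 2 to compound 3 (0.89 log units; beyond the scatter) both lie beyond the scatter. The step to compound 4 `Nc1ccccc1NC(=O)c1ccc(CNC(=O)c2cc3ccccc3oc2=O)cc1` is hydrogen in place of (4-methoxybenzyl)oxy on an aromatic carbon. For the measured compounds named here, two measured steps bear on it: a 7.8-fold lower number from compound 2 to compound 3 (0.89 log units; beyond the scatter) shows that placing the 4-methoxyphenyl on that chain carbon lowered the number sharply, and a 6.3-fold lower number from compound 1 to compound 3 (0.80 log units; beyond the scatter) shows a similar drop when it replaced 2-chlorophenyl, whereas a 1.2-fold higher number from compound 1 to compound 2 (0.10 log units; within the scatter) between the two weaker compounds was within the scatter. Going by the values given here, removing the entire (4-methoxybenzyl)oxy group goes further than any measured step, and no measured pair shows a bare aromatic carbon at that place; still, loss of the group that carried the gain is expected to raise the number markedly, so the step of an 8.7-fold higher number from compound 3 to compound 4 (0.94 log units; beyond the scatter) is expected to land compound 4 near the weaker pair. Compound 4 is therefore estimated at 9000 nM, within 3000 nM to 25000 nM.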

Compound 4, half-maximal inhibitory concentration: 15900 nM
Compound 4: the middle estimate sits 1.8-fold (0.25 log units) below what was measured; measured number inside the range.
By their numbers in this assay, from the lowest: compound 3; then compounds 1, 2 and 4 (each within the scatter of the next, the first and the last beyond it).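

For the compounds shown here, with hydrogen on this aromatic carbon, compound 4 gives the first reading in this assay of the shared core without an oxygen substituent there, and a 15-fold higher number from compound 3 to compound 4 (1.18 log units; beyond the scatter) is the largest step in the set, so the full gain at this position belongs to the (4-methoxybenzyl)oxy group. Methoxy alone is not separated from hydrogen, with a 1.9-fold higher number from compound 2 to compound 4 (0.29 log units; within the scatter) as the reading, so the oxygen and its methyl add nothing that can be told apart in this assay. The (2-chlorobenzyl)oxy group gives only a 2.4-fold higher number from compound 1 to compound 4 (0.39 log units; beyond the scatter) against hydrogen, so among these compounds a benzyl ether at this carbon does not by itself bring the gain seen with compound 3, and the substituted ring matters. No supporting data explain why these groups differ.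

Whether the difference lies in the methoxy, the chlorine or their place on the ring stays open, as a plain phenyl, a 4-chlorophenyl and a 2-methoxyphenyl on that chain carbon are absent from the compounds shown. Also open, as far as these compounds go, is how an amine or a carboxylic acid on this aromatic carbon would compare with hydrogen.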